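Swapping Chloro for Fluoro on a Shared Dicyano Core Series

This account rests on a few compounds, and the source may have more. Where it says the series, first, only, none or still open, it means among the compounds named here.

Of the compounds shown here, three have been measured in a functional assay on A-431 cells (Homo sapiens) for cytotoxicity, read by MTT assay; a higher number here means a weaker inhibitor, a lower number a stronger inhibitor. Compound 1 `N#Cc1c(Nc2ccccc2)c(Cl)c2nc(N)nc(N)c2c1F` gives 4.8 ug/mL there. Compound 2 `N#Cc1c(Nc2ccccc2)c(F)c2nc(N)nc(N)c2c1F` differs from it by fluoro in place of chloro on an aromatic carbon, and in this assay compound 2 gives 7 ug/mL, a step of a 1.5-fold higher number from compound 1 to compound 2 (0.16 log units; within the scatter). Compound 3 `CCN(CC)c1c(C#N)c(F)c2c(N)nc(N)nc2c1Cl` carries a different core, set apart from compound 1 by diethylamino in place of anilino on an aromatic carbon; in this assay compound 3 gives 7.3 ug/mL, a step of a 1.5-fold higher number from compound 1 to compound 3 (0.18 log units; within the scatter).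

Compound 4 `CCN(CC)c1c(C#N)c(F)c2c(N)nc(N)nc2c1F` is not yet measured. It differs from compound 3 by fluoro in place of chloro on an aromatic carbon. This is the same kind of change as that from compound 1 to compound 2, but not the same, since the place is ortho to a diethylamino group rather than ortho to an anilino group. For compound 4 a step of a 1.2-fold higher number from compound 3 to compound 4 (0.09 log units; within the scatter) in this assay is expected, resting on the earlier step of a 1.5-fold higher number from compound 1 to compound 2 (0.16 log units; within the scatter). The estimate for compound 4 in this assay is 9 ug/mL, between 4.5 ug/mL and 18 ug/mL.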

Compound 4, half-maximal inhibitory concentration: 16.4 ug/mL
Estimate against measurement, compound 4: 1.8-fold (0.26 log units) below, within the range that was stated.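

Fluoro in place of chloro carries from one core to the other in this assay, with both steps pointing the same way and agreeing in size: the same change on two cores in this assay, a 1.5-fold higher number (0.16 log units; within the scatter) from compound 1 to compound 2 and a 2.2-fold higher number (0.35 log units; beyond the scatter) from compound 3 to compound 4, 1.5-fold (0.19 log units) apart, within the scatter of two such steps

Diethylamino in place of anilino carries over in the same way: the same change on two cores in this assay, a 1.5-fold higher number (0.18 log units; within the scatter) from compound 1 to compound 3 and a 2.3-fold higher number (0.37 log units; beyond the scatter) from compound 2 to compound 4, 1.5-fold (0.19 log units) apart, within the scatter of two such steps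

Among the compounds shown here, the newer steps, a 2.2-fold higher number from compound 3 to compound 4 (0.35 log units; beyond the scatter) and a 2.3-fold higher number from compound 2 to compound 4 (0.37 log units; beyond the scatter), are modest, and these four compounds show agreement across only two cores, not a rule for other cores or a reason for the steps.

The compounds shown hold only anilino or diethylamino, and only chloro or fluoro, at the two changed places. Going by these compounds, whether dimethylamino or bromo would follow the same steps remains open.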